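The source may report more compounds than this note shows. Statements on the series, on what has been measured and on what is new or still open speak of the compounds shown alone.

The series rests on a shared core carrying a nitrile, an amino group and a methyl-substituted pyrrolidine, with an aminopyrazole that differs in what sits on its ring nitrogen. Compound 1 `Cc1nn(CC(C)(C)O)cc1Nc1nc(N)c2c(C#N)c(N3CCC[C@H]3C)n(C)c2n1` carries a 2-hydroxy-2-methylpropyl group there, and in an assay on HEK293 cells for inhibition of Leucine-rich repeat serine/threonine-protein kinase 2 variant G2019S (Homo sapiens), with a stated time of 48 h (on this read-out lower numbers stand for stronger inhibition and higher numbers for weaker inhibition), compound 1 gives 180 nM. Compound 2 `Cc1c(Nc2nc(N)c3c(C#N)c(N4CCC[C@H]4C)n(C)c3n2)cnn1[C@@H]1CCOC1` carries an oxolanyl group instead, and in this assay compound 2 gives 80 nM, a lower number than that of compound 1 by a gap that lies beyond the usual scatter. Of the two measured compounds, compound 1 therefore stands with the higher number.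

Compound 3 `Cc1nn(C)cc1Nc1nc(N)c2c(C#N)c(N3CCC[C@H]3C)n(C)c2n1` has not yet been measured. It differs from compound 1 by hydrogen in place of 1-hydroxy-1-methylethyl on a saturated chain carbon bound to an aromatic nitrogen, so that only a methyl remains on the ring nitrogen. Within the data shown here, no measured pair in this set shows a change of this kind, so nothing in the data fixes its size or direction. The step from compound 1 to compound 3 in this assay is expected to be a 1.1-fold higher number from compound 1 to compound 3 (0.05 log units; within the scatter), most likely within the scatter. Compound 3 is estimated at 200 nM, with a range from 70 nM to 600 nM.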

Compound 3, half-maximal inhibitory concentration: 120 nM
For compound 3 the middle estimate is 1.7-fold (0.22 log units) above the measured one, and the stated range covers the measured number.
By their numbers in this assay, from the lowest: compounds 2, 3 and 1 (each within the scatter of the next, the first and the last beyond it).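

Cutting the 2-hydroxy-2-methylpropyl group on the ring nitrogen back to methyl takes away the whole 1-hydroxy-1-methylethyl portion, with its hydrogen-bond donor and acceptor, and in this assay the step is a 1.5-fold lower number from compound 1 to compound 3 (0.18 log units; within the scatter). Among these compounds, this is the first pair that differs in one place, and it shows that on a saturated chain carbon bound to an aromatic nitrogen, a change from four heavy atoms to a lone hydrogen leaves compound 3 and compound 1 inseparable on this read-out, so this single pair gives no sign that the 1-hydroxy-1-methylethyl portion matters here. Nothing in the data explains why the two compounds lie so close together.

The compounds shown leave open how the read-out would respond to an amine or a carboxylic acid at the end of the chain on the ring nitrogen, or to a longer chain with no hydroxyl at all. They also leave open whether a straight 2-hydroxyethyl chain would behave like the 2-hydroxy-2-methylpropyl group or like the methyl.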